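A few compounds are considered here, and "the series" means these few. Any claim that something is new, unique, unknown or untested is made for them only; others in the source may bear on it.

Measured compounds:
- compound 1 `COc1ccc(Nc2nc(N)c(C(=O)c3cc(OC)c(OC)c(OC)c3)s2)cc1`: 1100 nM
- compound 2 `COc1ccc(Nc2nc(N)c(C(=O)c3ccccc3OC)s2)cc1`: 17 nM
- compound 3 `COc1ccc(Nc2nc(N)c(C(=O)c3ccc(OC)c(OC)c3)s2)cc1`: 10 nM

These three compounds share one core and differ only in how many methoxy groups sit on the ring attached to the carbonyl. In a functional assay on CCRF-CEM cells (Homo sapiens) for antiproliferative activity, read by cell counting, with a stated time of 2 days (a higher number here means a weaker inhibitor, a lower number a stronger inhibitor), compound 1 gives 1100 nM, compound 2 gives 17 nM, and compound 3 gives 10 nM. Compound 3 has the lowest number of the three; its gap to compound 2 lies within the scatter, while its gap to compound 1 lies beyond it, as the step of a 110-fold lower number from compound 1 to compound 3 (2.04 log units; beyond the scatter) shows.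

Compound 4 `COc1ccc(Nc2nc(N)c(C(=O)c3cccc(OC)c3)s2)cc1` has not yet been measured. It differs from compound 3 by hydrogen in place of methoxy on an aromatic carbon. For the measured compounds named here, the only step that bears on this change is a 110-fold lower number from compound 1 to compound 3 (2.04 log units; beyond the scatter), which went in the same direction as the removal here. Yet compound 2, which also carries a single methoxy, sits within the scatter of compound 3, so no large movement seems needed. For compound 4 the expected step is a 2.0-fold higher number from compound 3 to compound 4 (0.30 log units; within the scatter), essentially flat. Compound 4 is therefore estimated at 20 nM, with a range from 6 nM to 70 nM.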

Compound 4, half-maximal inhibitory concentration: 9.9 nM
For compound 4 the middle estimate is 2.0-fold (0.31 log units) above the measured one; low and high end bracket the measured number.
By their numbers in this assay, from the lowest: compounds 4, 3 and 2 (each within the scatter of the next); then compound 1.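

In this assay, taking away the methoxy group that stands ortho to a methoxy group and para to a large group leaves compound 3 and compound 4 indistinguishable, with a 1.0-fold lower number from compound 3 to compound 4 (0.00 log units; within the scatter), whereas the same kind of swap gave a large step in a 110-fold lower number from compound 1 to compound 3 (2.04 log units; beyond the scatter), so the outcome of removing a methoxy depends on the ring it is removed from. The single methoxy also tolerates a shift, as 3-methoxyphenyl in place of 2-methoxyphenyl gives a 1.7-fold lower number from compound 2 to compound 4 (0.23 log units; within the scatter), which again lies within the scatter. Nothing measured here offers an explanation for either result.

The compounds shown leave open whether the ring needs a methoxy group at all, as every one of them carries at least one. Also open, as far as these compounds go, is whether a hydroxyl group, a chlorine atom or an amine could take its place and keep the number this low.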